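One Change at the Sulfonyl Sulfur of Compound 1

This account rests on a few compounds, and the source may have more. Where it says the series, first, only, none or still open, it means among the compounds named here.

Among the measured compounds shown here, compound 1 `CC(C)COc1ncc(-c2cc(F)c(-c3nnc(S(=O)(=O)CC4CC4)[nH]3)cc2F)cc1Cl` is the only compound here with a full number in an ADME assay on microsomes from liver (Homo sapiens) for metabolic stability; on this read-out higher numbers stand for fast clearance and lower numbers for slow clearance; compound 1 gives 67 uL/min. Compound 2 `O=S(=O)(CC1CC1)c1nnc(-c2cc(F)c(-c3cnc(Oc4ccc(F)cc4F)c(Cl)c3)cc2F)[nH]1` sits at a limit of the assay in this assay, recorded as < 14 uL/min. For the measured compounds named here, the one measured step, an at least 4.7-fold lower number from compound 1 to compound 2 (0.67 log units; beyond the scatter), changes the group on an oxygen on an aromatic ring; since one end of it is the limit (the limit of < 14 uL/min in this assay, at which 1 of the 2 values shown sits), only its minimum size is known.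

Compound 3 `CC(C)COc1ncc(-c2cc(F)c(-c3nnc(S(=O)(=O)NC4CC4)[nH]3)cc2F)cc1Cl` differs from compound 1 elsewhere: cyclopropylamino in place of cyclopropylmethyl on a sulfonyl sulfur. The measured step does not touch the sulfonyl sulfur, so nothing measured bears directly on this change. Without a guide, the step expected here is a 1.2-fold lower number from compound 1 to compound 3 (0.09 log units; within the scatter), not beyond the scatter. Compound 3 is therefore estimated at 55 uL/min in this assay, expected to fall between 22 uL/min and 130 uL/min.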

Compound 3, intrinsic clearance in a liver preparation (reported as CLH), per the amount of preparation that the assay uses: 125 uL/min
Compound 3: middle estimate off by 2.3-fold (0.36 log units), on the low side, and the stated range covers the measured number.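

At the sulfonyl sulfur, the first measured swap, cyclopropylamino in place of cyclopropylmethyl, gives a 1.9-fold higher number from compound 1 to compound 3 (0.27 log units; within the scatter), so this assay does not separate these two groups, even though the entering group carries a hydrogen-bond donor that the leaving group lacks. This position therefore now has a measured step of its own, and the change on the oxygen remains the only step shown that lies beyond the scatter. Nothing at hand offers a reason for the reading at the sulfonyl sulfur.

On these data alone, whether a plain methyl, a longer chain or a dimethylamino group on the sulfonyl sulfur would read the same remains open. So does whether cyclopropylamino would read the same alongside the 2,4-difluorophenyl group of compound 2 as it does alongside the isobutyl group of compound 1.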